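From methoxy to pyrrolidin-1-yl on the triple-bond chain

The source may report more compounds than this note shows. Statements on the series, on what has been measured and on what is new or still open speak of the compounds shown alone.

In an ADME assay on HepG2 cells (Homo sapiens) for cytotoxicity (a higher number here means that more compound is tolerated, a lower number that less compound is tolerated), compound 3 `COCC#Cc1cc2ncnc(Nc3ccc(OCc4cccc(F)c4)c(Cl)c3)c2s1` reads > 33 uM, which is a limit and not a number. Compound 2 `CN(C)CC#Cc1cc2ncnc(Nc3ccc(OCc4cccc(F)c4)c(Cl)c3)c2s1` reads > 32 uM, also a limit. Compound 1 `CC(C)(C)CC#Cc1cc2ncnc(Nc3ccc(OCc4cccc(F)c4)c(Cl)c3)c2s1` gives a real number, 29.3 uM. Compound 4 `Fc1cccc(COc2ccc(Nc3ncnc4cc(C#CCN5CCCC5)sc34)cc2Cl)c1` has pyrrolidin-1-yl in place of methoxy on a saturated chain carbon bound to a triple-bonded carbon. The measured swaps at this place are an at least 1.0-fold higher number from compound 1 to compound 2 (0.03 log units; that floor lies within the scatter) and an at least 1.1-fold higher number from compound 1 to compound 3 (0.05 log units; that floor lies within the scatter), and neither floor leaves the scatter. The third swap, a step that the two limits leave unreadable from compound 2 to compound 3, cannot be sized. No change beyond the scatter is therefore expected, and the expected step is an at least 1.1-fold lower number from compound 3 to compound 4 (0.04 log units; that floor lies within the scatter). Compound 4 is estimated at 30 uM, with an expected range from 15 uM to 50 uM.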

Compound 4, half-maximal toxic concentration: 4.9 uM
Compound 4: middle estimate off by 6.1-fold (0.79 log units), on the high side, outside the stated range (below it).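

Pyrrolidin-1-yl stands apart from all three earlier groups in this assay, with an at least 6.7-fold lower number from compound 3 to compound 4 (0.82 log units; beyond the scatter) and an at least 6.5-fold lower number from compound 2 to compound 4 (0.81 log units; beyond the scatter) and also a 6.0-fold lower number from compound 1 to compound 4 (0.78 log units; beyond the scatter) (the only one of these read between two real numbers). The first two are floors, as compound 2 and compound 3 each read as a limit. Compound 2 also has a nitrogen at this place, in dimethylamino, without the low reading of compound 4, so a nitrogen alone does not decide the outcome.

As far as these compounds go, whether the ring itself matters stays open, and piperidin-1-yl or morpholin-4-yl at this place would bear on that. The data shown give no explanation for the drop.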